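The compounds below may be only part of what the source reports. "The series", "measured", "known", "first", "only" and "open" are said of these compounds alone.

Measured compounds:
- compound 1, `CCCc1nc(-c2ccccc2)c(CNCCN2CCN(c3ccccc3OC)CC2)o1`, giving 39.7%
- compound 2, `CCCc1nc(-c2ccccc2)c(CNCCCN2CCN(c3ccc(F)cc3)CC2)o1`, giving 62.5%
- compound 3, `Cc1nc(-c2ccccc2)c(CNCCN2CCN(C(c3ccccc3)c3ccccc3)CC2)o1`, giving 57.3%

In an assay on HEK293 cells for inhibition of Voltage-dependent T-type calcium channel subunit alpha-1G (Homo sapiens), read by fluorescence, tested at 10 uM (on this read-out lower numbers stand for less inhibition and higher numbers for more inhibition at the one concentration tested (going by the name of the read-out)), compound 2 stands at the top of the three numbers, yet its lead over compound 3 is small: compound 3 gives 57.3%, which lies within the usual scatter of the number for compound 2, so the two cannot be told apart. Going by the values given here, compound 1, with 39.7%, sits beyond the scatter below compound 2, and that is the only separation the three numbers support.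

Compound 4, `CCCc1nc(-c2ccccc2)c(CNCCCN2CCN(c3cccc(F)c3)CC2)o1`, shares all its atoms with compound 2 and differs only in how they are joined: 3-fluorophenyl in place of 4-fluorophenyl on an amine nitrogen in a ring

Among the compounds with values here, no pair of measured compounds shows this change on its own, so nothing here tells how much the number should move. With the fluorine shifted along the same ring and the rest of the molecule kept, the step from compound 2 to compound 4 in this assay is expected to stay inside the scatter, a number 4.5 percentage points lower from compound 2 to compound 4 (within the scatter), in no definite direction. Compound 4 is therefore estimated at 58% in this assay, within a range of 40% to 75%.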

Compound 4, a percentage reported as inhibition, at one concentration (the size of the read-out at that concentration, not a potency): 68.9%
Estimate against measurement, compound 4: 10.9 percentage points below, within the range that was stated.
By their numbers in this assay, from the lowest: compound 1; then compounds 3, 2 and 4 (each within the scatter of the next, the first and the last beyond it).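

In this assay, the exchange of 4-fluorophenyl for 3-fluorophenyl on the amine nitrogen in the ring comes to a number 6.4 percentage points higher from compound 2 to compound 4 (within the scatter), so the two compounds cannot be told apart. This is the first pair shown that differs in one place, and it gives the first direct reading of a change at this position: with the rest of the molecule kept, moving the fluorine around the ring leaves the inhibition at the one tested concentration indistinguishable, and the pair stays well clear of the number for compound 1. Nothing measured on these compounds bears on why the two fluorophenyl isomers read alike.

The compounds shown leave open whether this indifference holds only for fluorine or extends to larger groups on the same ring, such as a chlorine atom or a trifluoromethyl group in place of the fluorine. Going by these compounds alone, they also leave open how a longer chain in place of the propyl group on the shared core would read in this assay, as no pair here isolates a change at that place.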